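The source may hold more compounds than are shown below. What is called first, only, known or untested is meant among the compounds shown, and "the series" means these compounds.

In an assay on isolated protein with Polyunsaturated fatty acid 5-lipoxygenase (Homo sapiens) as the target (a lower number here means a stronger inhibitor, a higher number a weaker inhibitor), compound 3 `COC(C)c1cc(-c2ccccc2)c2ccc(OCc3cccc(C4(O)CCOCC4)c3)cc2c1` gives 1200 nM, the second highest of three numbers. Compound 1 `CC(O)c1cc(-c2ccccc2)c2ccc(OCc3cccc(C4(O)CCOCC4)c3)cc2c1` gives 520 nM and compound 2 `CC(C)(O)c1cc(-c2ccccc2)c2ccc(OCc3cccc(C4(O)CCOCC4)c3)cc2c1` gives 1500 nM. Compound 4 `CC(=O)c1cc(-c2ccccc2)c2ccc(OCc3cccc(C4(O)CCOCC4)c3)cc2c1` differs from compound 3 by acetyl in place of 1-methoxyethyl on an aromatic carbon. For the measured compounds named here, the steps that bear on this change both touch the same position: a 2.3-fold higher number from compound 1 to compound 3 (0.36 log units; beyond the scatter) and a 2.9-fold higher number from compound 1 to compound 2 (0.46 log units; beyond the scatter), while a 1.3-fold lower number from compound 2 to compound 3 (0.10 log units; within the scatter). Replacing the 1-methoxyethyl by acetyl removes the methyl on oxygen whose addition weakened compound 1, so a modest move toward a lower number is expected for compound 4, within a 1.5-fold lower number from compound 3 to compound 4 (0.18 log units; within the scatter). On that basis compound 4 is estimated at 800 nM, with a range from 300 nM to 2200 nM.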

Compound 4, half-maximal inhibitory concentration: 130 nM
Compound 4: the middle estimate sits 6.2-fold (0.79 log units) above what was measured; measured number below the stated range.
By their numbers in this assay, from the lowest: compound 4; then compound 1; then compounds 3 and 2 (each within the scatter of the next).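

In this assay acetyl is the only group shown at this aromatic carbon that gives a lower number than 1-hydroxyethyl, with a 4.0-fold lower number from compound 1 to compound 4 (0.60 log units; beyond the scatter) and with a 9.2-fold lower number from compound 3 to compound 4 (0.97 log units; beyond the scatter) and a 12-fold lower number from compound 2 to compound 4 (1.06 log units; beyond the scatter) as its steps from the other two. A hydroxyl at this position is therefore not needed for the lowest number in the set. The 1-methoxyethyl and acetyl groups have the same counts of hydrogen-bond donors and acceptors, so those counts do not account for the step between them.

From the compounds shown here alone, it remains open whether propanoyl, a carboxamide or a carboxylic acid at this carbon would keep the low number. Nothing available explains the gain from acetyl.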